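A few compounds are considered here, and "the series" means these few. Any claim that something is new, unique, unknown or untested is made for them only; others in the source may bear on it.

Working notes on the series. In a functional assay on SK-OV-3 cells (Homo sapiens) for cytotoxicity, read by MTT assay, with a stated time of 24 h (a higher number here means a weaker inhibitor, a lower number a stronger inhibitor), compound 1 (`CCCCCCCCCCCC(=O)Nc1nnc(S[C@@H]2O[C@H](COC(C)=O)[C@H](OC(C)=O)[C@H](OC(C)=O)[C@H]2OC(C)=O)s1`) gives "not active" (no number reported) and compound 3 (`CCCCCCCCCC(=O)Nc1nnc(S[C@@H]2O[C@H](COC(C)=O)[C@H](OC(C)=O)[C@H](OC(C)=O)[C@H]2OC(C)=O)s1`) gives "not active" (no number reported) here, so neither entry carries a number. Within the data shown here, compound 2 (`CCCCCCCC(=O)Nc1nnc(S[C@@H]2O[C@H](CO)[C@H](O)[C@H](O)[C@H]2O)s1`) gives 56000 nM as the only number, so it cannot be ranked by size against the other two. Compound 4 (`C=CCCCCCCCCC(=O)Nc1nnc(S[C@@H]2O[C@H](CO)[C@H](O)[C@H](O)[C@H]2O)s1`) is still unmeasured. Its change from compound 2 is allyl in place of hydrogen on a saturated chain carbon, seven bonds along the chain from a carbonyl carbon and amounts to allyl in place of hydrogen on a saturated chain carbon, seven bonds along the chain from a carbonyl carbon. Among the measured compounds shown here, no measured pair shows this change, so only a small strengthening is expected in this assay and possibly none beyond the scatter. The estimated step is a 1.6-fold lower number from compound 2 to compound 4 (0.20 log units; within the scatter) in size. For compound 4 the expected value is 35000 nM within an estimated range of 12000 nM to 90000 nM in this read-out.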

Compound 4, half-maximal inhibitory concentration: "not active" (no number reported)
Compound 4: no number reported, and the estimate cannot be compared.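

In this assay, among these compounds, compound 4 carries no number, so no step from compound 2 to compound 4 can be read. The compounds shown leave open what allyl in place of hydrogen does to this read-out, and no available evidence bears on the result.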